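A few compounds are considered here, and "the series" means these few. Any claim that something is new, unique, unknown or untested is made for them only; others in the source may bear on it.

Measured compounds: compound 1 `COc1ccc(CNCc2c(OC)cc(Oc3cccc(Nc4ccccc4)c3)cc2OC)cc1` with 1890 nM in a functional assay on HT-29 cells (Homo sapiens) for inhibition, read by MTT assay, with a stated time of 72 h (a lower number here means a stronger inhibitor, a higher number a weaker inhibitor), and compound 2 `COc1ccc(CCCNCc2c(OC)cc(Oc3cccc(Nc4ccccc4)c3)cc2OC)cc1` with 3320 nM in this assay.

Going by the values given here, compound 2 has the higher of the two numbers, but the single step, a 1.8-fold higher number from compound 1 to compound 2 (0.24 log units; within the scatter), lies within the scatter, so the two compounds cannot be told apart in this assay.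

Compound 3 `COc1cc(Oc2cccc(Nc3ccccc3)c2)cc(OC)c1CNCc1ccc(O)cc1` differs from compound 2 in one place: 4-hydroxyphenyl in place of 2-(4-methoxyphenyl)ethyl on a saturated chain carbon bound to an amine nitrogen. This change does two things at once: it returns the chain length to that of compound 1 and exchanges methoxy for hydroxy on the outer ring. Among the compounds with values here, only the step from compound 1 to compound 2 bears on it, and it covers only the chain length, where a 1.8-fold higher number from compound 1 to compound 2 (0.24 log units; within the scatter) showed no effect beyond the scatter. Within the data shown here, for the methoxy-to-hydroxy exchange there is no measured step at all. Compound 3 is therefore expected to land near compound 1, with a 1.7-fold lower number from compound 2 to compound 3 (0.22 log units; within the scatter) as the estimated step from compound 2. The estimate for compound 3 in this assay is 2000 nM, with a range from 700 nM to 6000 nM.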

Compound 3, half-maximal inhibitory concentration: 2180 nM
Estimate against measurement, compound 3: 1.1-fold (0.04 log units) below; the measured number falls inside the stated range.
By their numbers in this assay, from the lowest: compounds 1, 3 and 2 (each within the scatter of the next).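

Going by these compounds alone, compound 3 gives the first reading of hydroxy against methoxy on the outer ring: in this assay, hydrogen in place of methyl on an oxygen on an aromatic ring gives a 1.2-fold higher number from compound 1 to compound 3 (0.06 log units; within the scatter) and so cannot be told apart from no change. The broader replacement of 2-(4-methoxyphenyl)ethyl by 4-hydroxyphenyl on a saturated chain carbon bound to an amine nitrogen, which alters the chain and the ring substituent together, gives a 1.5-fold lower number from compound 2 to compound 3 (0.18 log units; within the scatter) and also stays inside the scatter, so neither this exchange nor the chain difference separates the three compounds in this assay. No measured evidence accounts for these results.

The compounds shown leave open whether another group on the outer ring, such as an amine, a carboxylic acid or a fluorine atom, or a chain longer than 3-(4-methoxyphenyl)propyl, would move the number beyond the scatter. They also leave open whether hydroxy would read the same on the longer chain, as it appears here only in 4-hydroxybenzyl.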